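Demethylation at selenium: compound 1 to compound 4

This account rests on a few compounds, and the source may have more. Where it says the series, first, only, none or still open, it means among the compounds named here.

Among the compounds with values here, compound 1 `COc1ccc(CNc2nc([Se]C)nc3ccccc23)cc1` is one of three compounds measured in a functional assay on CCRF-CEM cells (Homo sapiens) for cytotoxicity, read by MTT assay, with a stated time of 72 h; a higher number here means that more compound is tolerated, a lower number that less compound is tolerated. Compound 1 reaches only the limit of the assay, > 100000 nM. Compound 2 `C[Se]c1nc(N)c2ccccc2n1` likewise gives only a limit, > 100000 nM. Compound 3 `CSc1ccc(CNc2nc(SC)nc3ncccc23)cc1` gives a number, 59000 nM. Compound 1 thus stands at the limit of > 100000 nM in this assay, at which 2 of the 3 values shown sit, together with compound 2. Within the data shown here, no pair among the three differs in a single place, so no measured step exists. Compound 4 `COc1ccc(CNc2nc([SeH])nc3ccccc23)cc1` is the demethylated partner of compound 1: hydrogen in place of methyl on a selenium. Among the measured compounds shown here, with no measured step to lean on, the step for compound 4 is expected to be a number no higher from compound 1 to compound 4 (the limit leaves the size open), none beyond the scatter. Compound 4 is estimated at 100000 nM, between 30000 nM and 300000 nM, most likely reported again only as a limit.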

Compound 4, concentration lethal to 50% of the cells: > 100000 nM
Compound 4 was reported as a limit; the forecaster's own chance of this, stated with the estimate: 65%; the middle value lies on the limit itself.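

Compound 1 and compound 4 are both reported only as limits, so no step can be read between them. The compounds shown leave open how large any effect of hydrogen in place of methyl on a selenium is.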